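A few compounds are considered here, and "the series" means these few. Any claim that something is new, unique, unknown or untested is made for them only; others in the source may bear on it.

In a functional assay on K562 cells (Homo sapiens) for cytotoxicity, read by MTT assay, with a stated time of 3 days (on this read-out lower numbers stand for stronger inhibition and higher numbers for weaker inhibition), two compounds have been measured so far. Compound 1 `N#Cc1c(NN)nc(SCc2nc3ccccc3[nH]2)nc1-c1ccccc1` gives 14.7 nM. Compound 2 `N#Cc1c(-c2ccccc2)nc(SCc2nc3ccccc3[nH]2)nc1N1CCN(S(=O)(=O)c2ccccc2)CC1`, which carries a phenylsulfonyl group, gives 3 nM. That is the lower of the two numbers, and the gap to compound 1 lies beyond the scatter.

Compound 3 `N#Cc1c(-c2ccccc2)nc(SCc2nc3ccccc3[nH]2)nc1N1CCN(S(=O)(=O)c2ccccc2[N+](=O)[O-])CC1` has not yet been measured. It departs from compound 2 in one place, where phenylsulfonyl becomes (2-nitrophenyl)sulfonyl: nitro in place of hydrogen on an aromatic carbon.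

Within the data shown here, no measured pair in this small set shows what such a change does, so the expectation is loose. Compound 2 at 3 nM already stands low on this read-out, which leaves a slight lean towards a higher number. No step beyond the scatter is expected, and the estimated step of a 1.7-fold higher number from compound 2 to compound 3 (0.22 log units; within the scatter) reflects that lean. For compound 3 the expected value is 5 nM, with an estimated range from 1.5 nM to 16 nM.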

Compound 3, half-maximal inhibitory concentration: 14.7 nM
Compound 3: the middle estimate sits 2.9-fold (0.47 log units) below what was measured, within the range that was stated.
By their numbers in this assay, from the lowest: compound 2; then compounds 1 and 3 (each within the scatter of the next).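

In this assay, among these compounds, nitro in place of hydrogen on an aromatic carbon, ortho to a large group, turns phenylsulfonyl into (2-nitrophenyl)sulfonyl and gives a 4.9-fold higher number from compound 2 to compound 3 (0.69 log units; beyond the scatter) in the only pair that differs at this place. The earlier compounds shown here said nothing about this part of the molecule, whereas this pair shows that the six-membered aromatic ring of the phenylsulfonyl group is not a silent position: one added group moves the number beyond the scatter, towards weaker inhibition. Nothing available bears on the reason for this step.

A single substitution cannot show whether the step belongs to nitro in particular or would follow any group placed on this aromatic carbon, so the reading rests on one pair and stays modest. Going by these compounds, whether an amine, a methoxy group or a fluorine atom in place of the same hydrogen would move the number as far, or in the same direction, remains open, as does the effect of nitro on the other carbons of this ring.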